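The compounds below may be only part of what the source reports. "The series", "measured", "known", "first", "only" and "open" are said of these compounds alone.

Values in a functional assay on NCI-H146 cells (Homo sapiens) for cytotoxicity, with a stated time of 48 h, in the presence of a further agent that is not named here; a higher number here means that more compound is needed for the effect, a lower number that less compound is needed:
- compound 1 `CN(C)CC[C@H](CSc1ccccc1)Nc1ccc(S(=O)(=O)NC(=O)c2ccc(N3CCN(Cc4ccccc4-c4ccc(Cl)cc4)CC3)cc2)cc1S(=O)(=O)C(F)(F)F`: 39.4 nM
- compound 2 `CN(C)CC[C@H](CSc1ccccc1)Nc1ccc(S(=O)(=O)NC(=O)c2ccc(N3CCN(Cc4ccccc4-c4ccc(Cl)cc4)CC3)cc2)cc1C#N`: 1930 nM

Of the two measured compounds, compound 2 has the higher number, at 1930 nM. Compound 3 `CN(C)CC[C@H](CSc1ccccc1)Nc1ccc(S(=O)(=O)NC(=O)c2ccc(N3CCN(Cc4ccccc4-c4ccc(Cl)cc4)CC3)cc2)cc1C(=O)C(F)(F)F` carries (trifluoromethyl)carbonyl in place of cyano on an aromatic carbon. Among the measured compounds shown here, one measured step bears on this change: a 49-fold higher number from compound 1 to compound 2 (1.69 log units; beyond the scatter), which is large and beyond the scatter. It exchanges (trifluoromethyl)sulfonyl for cyano on that aromatic carbon. The entering group matches neither measured group, so a shift to a lower number is expected in this assay, of only part of that size. The estimated change is a 7.7-fold lower number from compound 2 to compound 3 (0.89 log units; beyond the scatter). The expected value for compound 3 is 250 nM, within an estimated range of 60 nM to 1000 nM.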

Compound 3, half-maximal effective concentration: 2010 nM
Compound 3: the middle estimate sits 8.0-fold (0.91 log units) below what was measured; measured number outside the range, above it.
By their numbers in this assay, from the lowest: compound 1; then compounds 2 and 3 (each within the scatter of the next).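

In this assay, (trifluoromethyl)carbonyl in place of cyano on this aromatic carbon gives a 1.0-fold higher number from compound 2 to compound 3 (0.02 log units; within the scatter), so these two groups cannot be told apart here. Against (trifluoromethyl)sulfonyl, the same group gives a 51-fold higher number from compound 1 to compound 3 (1.71 log units; beyond the scatter), so trifluoromethyl alone on a carbonyl does not reach the number of compound 1. Nothing at hand gives a cause for this. Open, going by these compounds, is whether the sulfonyl part, the trifluoromethyl part, or only both together carry the gap. A methylsulfonyl or a plain sulfonamide on this carbon would separate them.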